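Halide for methyl on the amide-bearing ring: compound 4

This account rests on a few compounds, and the source may have more. Where it says the series, first, only, none or still open, it means among the compounds named here.

Three compounds of the series have been run in a functional assay on K-562R cells (Homo sapiens) for cytotoxicity, read by XTT assay, with a stated time of 24 h; on this read-out higher numbers stand for weaker inhibition and lower numbers for stronger inhibition. Compound 1 `Cc1ccc(NC(=O)c2ccc(OCCCCn3ccnc3)c(Br)c2)cc1Nc1nccc(-c2cccnc2)n1` gives 31800 nM, compound 2 `COc1cc(C(=O)Nc2ccc(C)c(Nc3nccc(-c4cccnc4)n3)c2)ccc1OCCCCn1ccnc1` gives 27100 nM, and compound 3 `Cc1ccc(OCCCCn2ccnc2)c(C(=O)Nc2ccc(C)c(Nc3nccc(-c4cccnc4)n3)c2)c1` gives 48600 nM. The numbers for compound 3 sit alongside those of compound 1 and compound 2, each separated from it by less than the scatter, so no ordering among the three can be read from this assay. Among the measured compounds shown here, the single measured step, a 1.2-fold lower number from compound 1 to compound 2 (0.07 log units; within the scatter), is also within the scatter.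

Compound 4 `Cc1ccc(NC(=O)c2cc(I)ccc2OCCCCn2ccnc2)cc1Nc1nccc(-c2cccnc2)n1` differs from compound 3 as follows: iodo in place of methyl on an aromatic carbon. For the measured compounds named here, the one step that bears on this, a halogen exchanged for a non-halogen substituent on the same amide-bearing ring, a 1.2-fold lower number from compound 1 to compound 2 (0.07 log units; within the scatter), gave no movement beyond the scatter, and nothing else speaks to the position in question. No step beyond the scatter is therefore expected in this assay for compound 4.

Compound 4 is expected to give 40000 nM, within 15000 nM to 100000 nM. That estimate means a 1.2-fold lower number from compound 3 to compound 4 (0.08 log units; within the scatter), a step expected to lie within the scatter.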

Compound 4, half-maximal inhibitory concentration: 81700 nM
Beside the measured number, compound 4's estimate is 2.0-fold (0.31 log units) below it; measured number inside the range.
By their numbers in this assay, from the lowest: compounds 2, 1, 3 and 4 (each within the scatter of the next, the first and the last beyond it).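

In this assay, iodo in place of methyl on this aromatic carbon, meta to a large group and para to a 4-(1H-imidazol-1-yl)butoxy group, gives a 1.7-fold higher number from compound 3 to compound 4 (0.23 log units; within the scatter), which lies within the scatter. This is the first reading at this position, and it adds to a 1.2-fold lower number from compound 1 to compound 2 (0.07 log units; within the scatter), a step at a different place that also lies within the scatter, so neither single-place change shown separates its pair in this assay. Nothing available accounts for the size of the new step or ties it to either group.

With methyl and iodo the only groups shown on this carbon, it remains open whether an amine or a carboxylic acid there would give a step beyond the scatter. Also open, from the compounds shown here alone, is whether a longer chain carrying the imidazole would move the number.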